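Swapping a benzoyl for a 4-fluorophenyl on the core

This account rests on a few compounds, and the source may have more. Where it says the series, first, only, none or still open, it means among the compounds named here.

Measured compounds:
- compound 1, `O=C(NCCSCc1ccccc1)n1c(=O)oc2ccccc21`: 65 nM
- compound 2, `O=C(c1ccccc1)c1ccc2c(c1)oc(=O)n2C(=O)NCCCCc1ccccc1`: 29 nM

Both compounds were tested in an assay on HEK293 cells for inhibition of acid ceramidase (Homo sapiens), with a stated time of 10 min; on this read-out higher numbers stand for weaker inhibition and lower numbers for stronger inhibition. Compound 2 has the lower of the two numbers, and its gap to compound 1 is beyond the usual scatter, so compound 2 is the stronger inhibitor of the pair. Compound 3, `O=C(NCCCCc1ccccc1)n1c(=O)oc2cc(-c3ccc(F)cc3)ccc21`, has not yet been measured. It keeps the core and the four-carbon chain to phenyl of compound 2, and differs in one place: 4-fluorophenyl in place of benzoyl on an aromatic carbon. Among the compounds with values here, no measured pair shows this kind of change, so there is no direct guide to its effect. The step from compound 2 to compound 3 in this assay is therefore expected to be small, a 1.2-fold lower number from compound 2 to compound 3 (0.06 log units; within the scatter), with no clear direction beyond the scatter. Compound 3 is estimated to give 25 nM, with a range from 8 nM to 80 nM.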

Compound 3, half-maximal inhibitory concentration: 79 nM
For compound 3 the middle estimate is 3.2-fold (0.50 log units) below the measured one; measured number inside the range.
By their numbers in this assay, from the lowest: compound 2; then compounds 1 and 3 (each within the scatter of the next).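

In this assay, within the data shown here, 4-fluorophenyl in place of benzoyl gives a 2.7-fold higher number from compound 2 to compound 3 (0.44 log units; beyond the scatter), the first step that can be read at this position on an aromatic carbon of the core. The group held here therefore affects the number, although this step is modest and compound 3 still inhibits the enzyme. The swap removes the double bond outside aromatic rings and the hydrogen-bond acceptor counted in benzoyl and brings in fluorine, but no measurement shown explains the rise.

With several features changing in one step, the compounds shown do not separate the loss of the carbonyl from the gain of fluorine. Also open, on these data alone, is how an unsubstituted phenyl, an amine or a carboxylic acid at this position would compare with benzoyl.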